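Adding a Ring Methyl to a Phenolic Compound

The compounds below may be only part of what the source reports. "The series", "measured", "known", "first", "only" and "open" are said of these compounds alone.

Measured in a functional assay on Bel-7402 cells (Homo sapiens) for antiproliferative activity, read by MTT assay, with a stated time of 72 h; on this read-out lower numbers stand for stronger inhibition and higher numbers for weaker inhibition:
- Compound 1 `COc1cccc(CNCc2c(C(=O)O)n(Cc3ccc(C)cc3)c3cc(C)ccc23)c1`: 5670 nM
- Compound 2 `COc1ccc(Cn2c(C(=O)O)c(CNCc3cccc(OC)c3)c3ccccc32)cc1`: 52900 nM
- Compound 3 `COc1cccc(CNCc2c(C(=O)O)n(Cc3ccc(O)cc3)c3ccccc23)c1`: > 50000 nM, a limit

Compound 3 stands only at a limit of this assay, > 50000 nM, and not at an exact number. Compound 4 `COc1cccc(CNCc2c(C(=O)O)n(Cc3ccc(O)cc3)c3cc(C)ccc23)c1` differs from it in one place: methyl in place of hydrogen on an aromatic carbon. For the measured compounds named here, the only measured step reaching compound 3 is a step that the limit leaves unreadable from compound 2 to compound 3, which concerns another place. Compound 1 carries this methyl and gives 5670 nM, while compound 2 lacks it and gives 52900 nM. These two also differ in a second place, so this comparison is only a loose guide. Stronger inhibition is therefore expected, with an estimated at least 2.5-fold lower number from compound 3 to compound 4 (0.39 log units; beyond the scatter). For compound 4 the estimate is 20000 nM, with an expected range from 5000 nM to 70000 nM.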

Compound 4, half-maximal inhibitory concentration: > 50000 nM
Compound 4 gave a limit, no number; the forecaster's own chance of this, stated with the estimate: 30%; middle value at least 2.5-fold (0.39 log units) from the limit.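

In this assay compound 4 gives > 50000 nM, which is a limit and not a number. The ring methyl therefore does not bring this hydroxy compound to a readable value, and its effect here cannot be sized because compound 3 and compound 4 both sit at the limit: the limit of > 50000 nM in this assay, at which 2 of the 4 values shown sit.

With the ring methyl present in both compounds, hydroxy in place of methyl on an aromatic carbon gives an at least 8.8-fold higher number from compound 1 to compound 4 (0.94 log units; beyond the scatter). On these data alone, it remains open whether an ethyl group or an amine at the ring position would give a readable number alongside the hydroxy group.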